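Series notes: growth inhibition of the shared core

The source may report more compounds than this note shows. Statements on the series, on what has been measured and on what is new or still open speak of the compounds shown alone.

Compound 1 `COc1ccc(CNc2nc([Se]C)nc3ccccc23)cc1`, compound 2 `CCCCC[Se]c1nc(NCc2ccc(SC)cc2)c2ccccc2n1` and compound 3 `CCCCC[Se]c1nc([Se]CCCCC)c2ccccc2n1` have been run in an ADME assay on 184B5 cells (Homo sapiens) for cytotoxicity, read by MTT assay, with a stated time of 72 h; on this read-out lower numbers stand for stronger inhibition of growth and higher numbers for weaker inhibition of growth. Compound 1 reaches only the limit of this assay, > 100000 nM. Compound 2 likewise gives only a limit, > 100000 nM. Among the compounds with values here, compound 3 also stands at a limit, > 100000 nM, so no number is known for it; the limit of > 100000 nM in this assay, at which 3 of the 3 values shown sit, covers every value shown, and no step between measured compounds can be computed. Compound 4 `CCCCC[Se]c1nc(NCc2ccccc2)c2ccccc2n1` awaits this assay; it differs from compound 3 by a group of 8 heavy atoms (7 carbon, 1 nitrogen; one six-membered aromatic ring of carbon only) in place of a group of 6 heavy atoms (5 carbon, 1 selenium; no ring), on an aromatic carbon, in words a group of 8 heavy atoms (7 carbon, 1 nitrogen; one six-membered aromatic ring of carbon only) in place of a group of 6 heavy atoms (5 carbon, 1 selenium; no ring), on an aromatic carbon. With all three values at a limit, no step beyond the scatter is expected in this assay. Compound 4 is accordingly expected to sit at about 100000 nM, in the range 40000 nM to 300000 nM. The expected step of a number no higher from compound 3 to compound 4 (the limit leaves the size open) is none.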

Compound 4, concentration for total growth inhibition: > 100000 nM
Compound 4: only a limit was reported; the forecaster's own chance of this, stated with the estimate: 75%; the middle value lies on the limit itself.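

No step can be read from compound 2 or compound 3 to compound 4 in this assay, because all the values are limits: the limit of > 100000 nM in this assay, at which 4 of the 4 values shown sit.

The compounds shown leave open the actual value of each compound and whether any change on the shared core shifts growth inhibition.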